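The source may report more compounds than this note shows. Statements on the series, on what has been measured and on what is new or still open speak of the compounds shown alone.

Compound 1 `O=C1NCCN1c1ccc(S(=O)(=O)Nc2cccc(Br)c2)cc1`: 290 nM
Compound 2 `Cc1ccc(C)c(NS(=O)(=O)c2ccc(N3CCNC3=O)cc2)c1`: 110 nM

In a functional assay on MDA-MB-231 cells (Homo sapiens) for antiproliferative activity, read by sulforhodamine B assay, with a stated time of 48 h (on this read-out lower numbers stand for stronger inhibition and higher numbers for weaker inhibition), compound 2 holds the lower of the two numbers at 110 nM, while compound 1 gives 290 nM. Compound 3 `O=C1NCCN1c1ccc(S(=O)(=O)Nc2cccc(Cl)c2)cc1` has not yet been measured. It departs from compound 2 as follows: 3-chlorophenyl in place of 2,5-dimethylphenyl on a sulfonamide nitrogen. In words, it has 3-chlorophenyl in place of 2,5-dimethylphenyl on a sulfonamide nitrogen. Among the measured compounds shown here, one measured step bears on this change: a 2.6-fold lower number from compound 1 to compound 2 (0.42 log units; beyond the scatter), which came with 2,5-dimethylphenyl in place of 3-bromophenyl on a sulfonamide nitrogen. The new change removes that same 2,5-dimethylphenyl, so a modest step of similar size is expected in this assay, toward a higher number and weaker inhibition. For the measured compounds named here, no measurement yet shows how 3-chlorophenyl itself behaves. The expected step is a 2.5-fold higher number from compound 2 to compound 3 (0.41 log units; beyond the scatter). For compound 3 the estimated value is 280 nM, with an expected range from 120 nM to 650 nM.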

Compound 3, half-maximal inhibitory concentration: 200 nM
For compound 3 the middle estimate is 1.4-fold (0.15 log units) above the measured one; the measured number falls inside the stated range.
By their numbers in this assay, from the lowest: compounds 2, 3 and 1 (each within the scatter of the next, the first and the last beyond it).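

In this assay, 3-chlorophenyl in place of 2,5-dimethylphenyl on a sulfonamide nitrogen gives a 1.8-fold higher number from compound 2 to compound 3 (0.26 log units; within the scatter), so these two aryl groups cannot be separated at this position. Chloro in place of bromo on an aromatic carbon gives a 1.5-fold lower number from compound 1 to compound 3 (0.16 log units; within the scatter), so this exchange of halogens cannot be resolved here either. Among the compounds shown here, the only step beyond the scatter remains a 2.6-fold lower number from compound 1 to compound 2 (0.42 log units; beyond the scatter), and compound 3 now lies within the scatter of both compounds, which leaves little basis for a firm ranking of the three aryl groups.

Nothing available accounts for these numbers. On these data alone, it remains open whether an unsubstituted phenyl, a methoxy group, an amine or a carboxylic acid on this aryl ring would stay within this narrow span of values.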